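A longer, unsaturated chain on compound 2

The source may report more compounds than this note shows. Statements on the series, on what has been measured and on what is new or still open speak of the compounds shown alone.

In a functional assay on HepG2 cells (Homo sapiens) for cytotoxicity (on this read-out higher numbers stand for lower toxicity in this test and lower numbers for higher toxicity in this test), compound 1 `CCCCCCCC(=O)Nc1nc(N)nc2c1ncn2[C@H]1CO[C@@H](CO)O1` gives > 100000 nM, which is a limit of the assay and not a number. Going by the values given here, compound 2 `CCCCCCCCCCCCCC(=O)Nc1nc(N)nc2c1ncn2[C@H]1CO[C@@H](CO)O1` gives 56000 nM, the only actual number so far. Compound 3 `CCCCCCCC/C=C\CCCCCCCC(=O)Nc1nc(N)nc2c1ncn2[C@H]1CO[C@@H](CO)O1` carries dec-1-en-1-yl in place of hexyl on a saturated chain carbon, seven bonds along the chain from a carbonyl carbon. Among the compounds with values here, the one measured step that bears on this change is an at least 1.7-fold lower number from compound 1 to compound 2 (0.25 log units; that floor lies within the scatter), which also extends the chain at this place. A small further move toward lower numbers therefore seems likely, perhaps none beyond the scatter. The expected step is a 1.4-fold lower number from compound 2 to compound 3 (0.15 log units; within the scatter). For compound 3 the estimated value is 40000 nM, with an expected range of 15000 nM to 100000 nM.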

Compound 3, half-maximal cytotoxic concentration: 11000 nM
The estimate for compound 3 lay 3.6-fold (0.56 log units) above the measured number; measured number below the stated range.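

In this assay, dec-1-en-1-yl in place of hexyl on a saturated chain carbon, seven bonds along the chain from a carbonyl carbon, gives a 5.1-fold lower number from compound 2 to compound 3 (0.71 log units; beyond the scatter) and so shows a change at this place that clearly exceeds the scatter, which the earlier step could not show. The full change is an at least 9.0-fold lower number from compound 1 to compound 3 (0.95 log units; beyond the scatter) and is only a floor, since compound 1 gives a limit and not a number: the limit of > 100000 nM in this assay, at which 1 of the 3 values shown sits.

Added length and the double bond arrive together in compound 3, so their separate shares cannot be told apart. Also open, going by these compounds, is how a saturated chain of the same length, or a chain carrying an amine or a carboxylic acid, would read.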